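The source may hold more compounds than are shown below. What is called first, only, known or untested is meant among the compounds shown, and "the series" means these compounds.

Measured compounds:
- compound 1 `CC1CCN(C2CCN(S(=O)(=O)c3cccc(-c4ccc(F)cc4)c3)CC2)CC1`: 12 nM
- compound 2 `COc1cc(C)ccc1S(=O)(=O)N1CCC(N2CCC(C)CC2)CC1`: > 5000 nM
- compound 3 `Cc1cc(S(=O)(=O)N2CCC(N3CCC(C)CC3)CC2)c(Cl)cc1Cl`: 2 nM

In a functional assay on DLD-1 cells (Homo sapiens) for antiproliferative activity, read by CellTiter-Glo, with a stated time of 72 h (a higher number here means a weaker inhibitor, a lower number a stronger inhibitor), compound 1 gives 12 nM, the higher of the two numbers obtained; the nearest value belongs to compound 3, which gives 2 nM, a gap that lies beyond the usual scatter of this assay. Compound 2 reaches only the limit of the assay, > 5000 nM, and no number is known for it (the limit of > 5000 nM in this assay, at which 1 of the 3 values shown sits).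

The step now followed goes from compound 1 to compound 4 `COc1cccc(S(=O)(=O)N2CCC(N3CCC(C)CC3)CC2)c1`, which has not yet been tested in this assay. The change is methoxy in place of 4-fluorophenyl on an aromatic carbon: the large 4-fluorophenyl group is gone, and a small methoxy group stands in its place, meta to a large group on the same aromatic ring.

Among the measured compounds shown here, since no measured pair shows this exact exchange, the expectation rests on the three values alone. Compound 2, which also carries a methoxy group and no second ring, gives only the limit > 5000 nM. Compound 4 is therefore expected to be a much weaker inhibitor than compound 1, with an estimated step of a 210-fold higher number from compound 1 to compound 4 (2.32 log units; beyond the scatter). For compound 4 the expected value in this assay is 2500 nM, in a range from 400 nM to 15000 nM.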

Compound 4, half-maximal inhibitory concentration: > 5000 nM
Compound 4 gave a limit, no number; the forecaster's own chance of this, stated with the estimate: 40%; middle value at least 2.0-fold (0.30 log units) from the limit.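

Among the compounds shown here, this is the first exchange at this position that can be read as a single change on the shared core. With methoxy in place of 4-fluorophenyl on an aromatic carbon, meta to a large group, this assay gives an at least 410-fold higher number from compound 1 to compound 4 (2.61 log units; beyond the scatter), so the 4-fluorophenyl group cannot be swapped for methoxy here without a large change in the read-out. The size of that step is only a lower bound, as the value of compound 4 is a limit of the assay and not a number, and such a result is no longer a single case: the limit of > 5000 nM in this assay, at which 2 of the 4 values shown sit.

The compounds shown leave open what a cyclohexyl group or a pyridyl ring would give on this same carbon, and so whether the aromatic ring, its fluorine or simply a larger group carries the effect. Compound 3 gives 2 nM without a 4-fluorophenyl group, but it differs from compound 4 in more than one place, so it cannot show which ring substituents could stand in for that group.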